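A few compounds are considered here, and "the series" means these few. Any claim that something is new, unique, unknown or untested is made for them only; others in the source may bear on it.

The study concerns a small set of compounds built on one shared core. Compound 1 `Cc1ccc(-c2c(C)c(-c3ccc(C)c(C)c3)c(C(OC(C)(C)C)C(=O)O)c(C)c2NC(=O)c2ccccc2)cc1C` carries a benzoyl group on the ring nitrogen, and in an ADME assay on MT4 cells (Homo sapiens) for cytotoxicity, read by MTT assay, with a stated time of 4 days (on this read-out lower numbers stand for higher toxicity in this test and higher numbers for lower toxicity in this test), compound 1 gives 9100 nM. Within the data shown here, its only measured neighbour is compound 2 `Cc1ccc(-c2c(C)c(-c3ccc(C)c(C)c3)c(C(OC(C)(C)C)C(=O)O)c(C)c2NC(=O)Nc2ccccc2)cc1C`, which in this assay gives 8000 nM; the two numbers sit within the scatter of one another, as the step of a 1.1-fold lower number from compound 1 to compound 2 (0.06 log units; within the scatter) shows, so compound 1 is neither set apart from nor ordered against compound 2 on this read-out.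

The step now followed leads from compound 1 to compound 3 `Cc1ccc(-c2c(C)c(-c3ccc(C)c(C)c3)c(C(OC(C)(C)C)C(=O)O)c(C)c2NS(=O)(=O)c2ccccc2)cc1C`. The structural change is phenylsulfonyl in place of benzoyl on a nitrogen on an aromatic ring. Among the measured compounds shown here, no measured step in this set exchanges the benzoyl group for a sulfonyl group; the one step that is known, a 1.1-fold lower number from compound 1 to compound 2 (0.06 log units; within the scatter), alters the same attachment on the nitrogen in a different way and stays within the scatter. On that basis no movement beyond the scatter is expected in this assay, and the step of a 1.0-fold lower number from compound 1 to compound 3 (0.00 log units; within the scatter) is the expectation. Compound 3 is therefore estimated at 9000 nM, with a range from 4000 nM to 20000 nM.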

Compound 3, half-maximal cytotoxic concentration: 11000 nM
For compound 3 the middle estimate is 1.2-fold (0.09 log units) below the measured one, and the stated range covers the measured number.
By their numbers in this assay, from the lowest: compounds 2, 1 and 3 (each within the scatter of the next).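

In this assay, the phenylsulfonyl group on this nitrogen on an aromatic ring can now be set against both earlier groups: its exchange for benzoyl gives a 1.2-fold higher number from compound 1 to compound 3 (0.08 log units; within the scatter), and its exchange for phenylcarbamoyl gives a 1.4-fold higher number from compound 2 to compound 3 (0.14 log units; within the scatter). The earlier pair showed only that benzoyl and phenylcarbamoyl could not be told apart on this read-out, whereas all three groups now fall within the scatter of one another, even though the attachment to the nitrogen differs in each and phenylsulfonyl brings a sulfur atom and a second double bond outside aromatic rings. Nothing available offers an explanation for this result.

All three groups carry a six-membered aromatic ring of carbon only, so the compounds shown leave open whether an acetyl group, a methanesulfonyl group or a free amine at the same place would stay within the scatter of these values. They also leave open whether a chlorine atom or a methoxy group on that phenyl ring would move the number beyond the scatter.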